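The source may report more compounds than this note shows. Statements on the series, on what has been measured and on what is new or still open speak of the compounds shown alone.

Working notes on the series. In a functional assay on A549 cells (Homo sapiens) for inhibition, read by sulforhodamine B assay, with a stated time of 48 h (a higher number here means a weaker inhibitor of growth, a lower number a stronger inhibitor of growth), compound 1 (`COc1ccc(/C=C/C(=O)C(=Cc2ccc(F)cc2)C(=O)/C=C/c2ccc(OC)c(OC)c2)cc1OC`) gives 550 nM, compound 2 (`COc1ccc(OC)c(C=C(C(=O)/C=C/c2ccc(O)c(OC)c2)C(=O)/C=C/c2ccc(O)c(OC)c2)c1`) gives 670 nM and compound 3 (`COc1ccc(OC)c(C=C(C(=O)/C=C/c2ccc(OC)c(OC)c2)C(=O)/C=C/c2ccc(OC)c(OC)c2)c1`) gives 530 nM. Compound 2 lies within the scatter of both others, so these three values do not separate.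

Compound 4 (`COc1cccc(C=C(C(=O)/C=C/c2ccc(O)c(OC)c2)C(=O)/C=C/c2ccc(O)c(OC)c2)c1`) is still unmeasured and differs from compound 2 in one place: hydrogen in place of methoxy on an aromatic carbon. Hydrogen stands in place of methoxy on an aromatic carbon, ortho to a large group and para to a methoxy group, which turns 2,5-dimethoxyphenyl into 3-methoxyphenyl.

For the measured compounds named here, one measured step concerns this same group: a 1.0-fold lower number from compound 1 to compound 3 (0.02 log units; within the scatter), with 2,5-dimethoxyphenyl in place of 4-fluorophenyl. That exchange of the whole group stays within the scatter. Going by the values given here, no measured step removes a single methoxy, so the evidence is indirect and the range is kept wide.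

On these data alone, on that basis, no step beyond the scatter is expected in this assay, and the direction remains open. The expected size is a 1.1-fold lower number from compound 2 to compound 4 (0.05 log units; within the scatter). Compound 4 is estimated at 600 nM, with an expected range of 280 nM to 1300 nM.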

Compound 4, concentration for 50% growth inhibition: 640 nM
The estimate for compound 4 lay 1.1-fold (0.03 log units) below the measured number; the range from low to high includes it.
By their numbers in this assay, from the lowest: compounds 3, 1, 4 and 2 (each within the scatter of the next).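

In this assay, the methoxy ortho to a large group and para to a methoxy group now has a direct reading: hydrogen in its place, which turns 2,5-dimethoxyphenyl into 3-methoxyphenyl, gives a 1.0-fold lower number from compound 2 to compound 4 (0.02 log units; within the scatter). The earlier step exchanged the whole group, so it could not isolate this one methoxy; here a single substituent changes on the core of compound 2, and the assay does not separate the pair. No measurement of any property of these compounds bears on this result.

The compounds shown leave open whether hydrogen in place of this methoxy would read the same on the core of compound 3, where the two outer aromatic groups differ from those of compound 2, and whether the remaining methoxy of compound 4 can also give way to hydrogen without a step beyond the scatter. They also leave open how an amine or a carboxylic acid on this same aromatic carbon would read in this assay.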